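Isopropyl to cyclohexyl in a clearance series

A few compounds are considered here, and "the series" means these few. Any claim that something is new, unique, unknown or untested is made for them only; others in the source may bear on it.

Of the compounds shown here, three have numbers so far in an ADME assay (liver) for metabolic stability, with Liver microsome (Rattus norvegicus) as the target, using microsomes and NADPH, with a stated time of 30 min, at 37 degrees C, tested at 1 uM; on this read-out higher numbers stand for fast clearance and lower numbers for slow clearance. Compound 3 (`CC(C)Nc1nc(S(=O)(=O)c2ccc(N)nc2)ccc1-c1ccc(C(C)(O)C(F)(F)F)cn1`) gives 62 mL.min-1.g-1 and sits within the usual scatter of compound 2 (`CCNc1nc(S(=O)(=O)c2ccc(N)nc2)ccc1-c1ccc(C(C)(O)C(F)(F)F)cn1`) at 42 mL.min-1.g-1 on this scale. Compound 1 (`CC#Cc1cc(C(O)(C(F)(F)F)C(F)(F)F)cnc1-c1ccc(S(=O)(=O)c2ccc(N)nc2)cc1`) gives 177 mL.min-1.g-1 and so reads higher than compound 3 by more than the scatter. No single change links compound 1 to the other two, so it says little about the question here.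

That question concerns compound 4 (`CC(O)(c1ccc(-c2ccc(S(=O)(=O)c3ccc(N)nc3)nc2NC2CCCCC2)nc1)C(F)(F)F`), which has not yet been measured. It carries cyclohexyl in place of isopropyl on a nitrogen on an aromatic ring. For the measured compounds named here, only one measured step touches the group on that nitrogen. It is a 1.5-fold higher number from compound 2 to compound 3 (0.17 log units; within the scatter) and came from a methyl in place of a hydrogen on a saturated chain carbon. One step of that size shows no trend. Cyclohexyl brings in more carbon than that methyl did, so a small rise is expected rather than a fall, though this is a weak guide. The expected step is a 1.6-fold higher number from compound 3 to compound 4 (0.21 log units; within the scatter) and it may well stay inside the scatter. The estimate for compound 4 is 100 mL.min-1.g-1 with 50 mL.min-1.g-1 to 200 mL.min-1.g-1 as the expected range.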

Compound 4, intrinsic clearance in microsomes: 280 mL.min-1.g-1
The estimate for compound 4 lay 2.8-fold (0.45 log units) below the measured number, outside the stated range (above it).
By their numbers in this assay, from the lowest: compounds 2 and 3 (each within the scatter of the next); then compounds 1 and 4 (each within the scatter of the next).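

At this position, on a nitrogen on an aromatic ring, the group does change the clearance number in this assay: cyclohexyl in place of isopropyl gives a 4.5-fold higher number from compound 3 to compound 4 (0.65 log units; beyond the scatter), and cyclohexyl in place of ethyl gives a 6.7-fold higher number from compound 2 to compound 4 (0.82 log units; beyond the scatter). For the compounds shown here, the one earlier step on this nitrogen (a 1.5-fold higher number from compound 2 to compound 3 (0.17 log units; within the scatter)) could not show this, so the position can now be seen to respond to a change of group, at least for this larger one, which brings a six-membered non-aromatic ring of carbon only and more carbon than isopropyl. Nothing measured here explains why the number moves on this change.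

Cyclohexyl differs from isopropyl both in its carbon count and in having a ring, and these three compounds cannot separate the two. An open hexyl chain would test the carbon count without the ring, a cyclopentyl ring would show whether a smaller ring behaves the same way, and a tetrahydropyranyl ring would show what an oxygen in the ring does to the number.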